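Ether side-chain changes: estimate for compound 4

This account rests on a few compounds, and the source may have more. Where it says the series, first, only, none or still open, it means among the compounds named here.

Measured compounds:
compound 1, `COCCOc1cc2oc(=O)n(CCC(=O)O)c2cc1Cl`, 31.6 nM
compound 2, `O=C(O)CCn1c(=O)oc2cc(OCC3CCC3)c(Cl)cc21`, 25.1 nM
compound 3, `C[C@@H](Oc1cc2oc(=O)n(CCC(=O)O)c2cc1Cl)c1cccnn1`, 1.26 nM

In an assay for inhibition of kynurenine 3-monooxygenase (Homo sapiens), read by mass spectrometry, with a stated time of 1 h (a lower number here means a stronger inhibitor, a higher number a weaker inhibitor), compound 3 stands lowest of the three numbers; the steps of a 25-fold lower number from compound 1 to compound 3 (1.40 log units; beyond the scatter) and a 20-fold lower number from compound 2 to compound 3 (1.30 log units; beyond the scatter) are both large, while a 1.3-fold lower number from compound 1 to compound 2 (0.10 log units; within the scatter) is within the scatter. Compound 4, `Cc1ccnc([C@@H](C)Oc2cc3oc(=O)n(CCC(=O)O)c3cc2Cl)c1`, differs from compound 3 by 4-methylpyridin-2-yl in place of pyridazin-3-yl on a saturated chain carbon bound to an oxygen on an aromatic ring and a saturated chain carbon. Going by the values given here, no measured step exchanges one aromatic ring for another, so the two large steps bear on it only indirectly: they show that the aromatic ring group outperforms the chain and small-ring groups, and compound 4 keeps an aromatic ring in the same place. The expected step is therefore none beyond the scatter, a 1.3-fold higher number from compound 3 to compound 4 (0.10 log units; within the scatter). Compound 4 is estimated at 1.6 nM, with a range from 0.5 nM to 5 nM.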

Compound 4, half-maximal inhibitory concentration: 3.98 nM
Compound 4: middle estimate off by 2.5-fold (0.40 log units), on the low side, and the stated range covers the measured number.
By their numbers in this assay, from the lowest: compound 3; then compound 4; then compounds 2 and 1 (each within the scatter of the next).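

In this assay, the aromatic rings at this place are not interchangeable: a 3.2-fold higher number from compound 3 to compound 4 (0.50 log units; beyond the scatter), with 4-methylpyridin-2-yl in place of pyridazin-3-yl. The earlier steps shown here set an aromatic ring only against chain and small-ring groups, whereas this one separates two aromatic rings, and compound 4 at 3.98 nM still lies well under compound 2 at 25.1 nM. No evidence on the cause of this step is available.

Going by these compounds, the change alters the ring nitrogen count and adds a methyl together, so the share of each remains open. An unsubstituted pyridin-2-yl would separate the two.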